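Cyano in place of nitro: working notes on compound 4

The source may hold more compounds than are shown below. What is called first, only, known or untested is meant among the compounds shown, and "the series" means these compounds.

Measured in a functional assay on the whole organism for inhibition, with Rattus norvegicus as the target, in the maximal electroshock model, at a dose of 25 mg/kg by the intraperitoneal route; a lower number here means less inhibition, a higher number more inhibition at the dose given (going by the name of the read-out):
compound 1 `CN(C)c1ncnc2c1ncn2CC1CCCCC1` gives 0%
compound 2 `CN(c1ncnc2c1ncn2Cc1ccccc1)C1CCCC1` gives 17%
compound 3 `CN(C)c1ncnc2c1ncn2Cc1cccc([N+](=O)[O-])c1` gives 17%

Compound 3 stands level with compound 2 at the digits recorded, the two together the highest of the three numbers. Its nearest neighbour is compound 2, with no change at the digits recorded and within the scatter; its furthest is compound 1, whose number lies lower by a gap beyond the scatter. No pair of these compounds differs in one place only, so no measured step is available to guide the next change.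

Compound 4 `CN(C)c1ncnc2c1ncn2Cc1cccc(C#N)c1` has not yet been measured in this assay. It differs from compound 3 as follows.
cyano in place of nitro on an aromatic carbon
The remainder of the two structures is shared. Going by the values given here, with no measured step of this kind on hand, and with compound 3 at 17%, the expectation is for no step beyond the scatter, a number 2 percentage points lower from compound 3 to compound 4 (within the scatter). Compound 4 is expected to give 15%, with a range from 0% to 35%.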

Compound 4, a percentage reported as inhibition, in the whole organism at one dose (the size of the read-out at that dose, not a potency): 17%
Compound 4: the middle estimate sits 2 percentage points below what was measured, and the stated range covers the measured number.
By their numbers in this assay, from the lowest: compound 1; then compounds 2, 3 and 4 (each within the scatter of the next).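

In this assay, going by these compounds alone, the first single-place comparison shows no change at the digits printed from compound 3 to compound 4 (within the scatter) on exchanging nitro for cyano on an aromatic carbon, meta to a large group. At this place the read-out therefore does not separate the two groups, although cyano has fewer heavy atoms and fewer hydrogen-bond acceptors than nitro. The oxygen atoms of nitro are thus not needed to keep the number at this dose, though nothing measured here bears on why the two groups read alike.

As far as these compounds go, it remains open whether an amine, a carboxylic acid or a methoxy group at this same place would read alike or would move the number beyond the scatter. Also open, from the compounds shown here alone, is whether the exchange of nitro for cyano would read the same on a shared core carrying a different amine.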